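The source may hold more compounds than are shown below. What is called first, only, known or untested is meant among the compounds shown, and "the series" means these compounds.

Compound 2 `COc1ccc(N2CCN(C(=S)SCc3ccc(C(=O)Nc4ccccc4N)cc3)CC2)cc1` shows in a functional assay on A-375 cells (Homo sapiens) for antiproliferative activity, read by CCK-8 assay, with a stated time of 72 h, tested at 2 uM (a higher number here means a stronger effect of the compound at the concentration tested, a lower number a weaker effect), a value of 28.1%, the highest of the three numbers at hand, although the gaps to its neighbours lie within the scatter. Compound 3 `Nc1ccccc1NC(=O)c1ccc(CSC(=S)N2CCCc3ccccc32)cc1` gives 26.5% in this assay, and compound 1 `Nc1ccccc1NC(=O)c1ccc(CSC(=S)N2CCN(Cc3ccccn3)CC2)cc1` gives 20.7%. Among the compounds with values here, the one step between measured compounds, a number 7.4 percentage points higher from compound 1 to compound 2 (within the scatter), changed a group on the amine nitrogen in the ring and stayed within the scatter. Compound 4 `Cc1ccc(N2CCN(C(=S)SCc3ccc(C(=O)Nc4ccccc4N)cc3)CC2)cc1` differs from compound 2 by methyl in place of methoxy on an aromatic carbon. Within the data shown here, no measured step touches this aromatic carbon, so the account rests on the small effect of the one step seen. For compound 4 the expected step of a number 1.1 percentage points lower from compound 2 to compound 4 (within the scatter) is none beyond the scatter, and its value in this assay is estimated at 27%, between 17% and 37%.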

Compound 4, a percentage reported as inhibition, at one concentration (the size of the read-out at that concentration, not a potency): 25.8%
For compound 4 the middle estimate is 1.2 percentage points above the measured one, within the range that was stated.
By their numbers in this assay, from the lowest: compounds 1, 4, 3 and 2 (each within the scatter of the next).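

In this assay, the change from 4-methoxyphenyl to 4-methylphenyl gives a number 2.3 percentage points lower from compound 2 to compound 4 (within the scatter), so at this aromatic carbon, para to a large group, removing the oxygen of the methoxy leaves the read-out within the scatter. Set against (pyridin-2-yl)methyl on the amine nitrogen in the ring, 4-methylphenyl gives a number 5.1 percentage points higher from compound 1 to compound 4 (within the scatter), so these two groups are not separated either. Nothing on hand explains either step. From the compounds shown here alone, whether an amine, a carboxylic acid or a chlorine at this carbon would move the number beyond the scatter stays open. The single tested concentration also leaves potency open.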